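This account rests on a few compounds, and the source may have more. Where it says the series, first, only, none or still open, it means among the compounds named here.

Measured compounds:
compound 1 `CCCCOC(=O)Nc1ccc([Se]C#N)cc1`: 5300 nM
compound 2 `CCOC(=O)Nc1ccc([Se][Se]c2ccc(NC(=O)OCC)cc2)cc1`: 5700 nM

In an ADME assay on 184B5 cells (Homo sapiens) for cytotoxicity, read by MTT assay, with a stated time of 72 h (a higher number here means a weaker inhibitor of growth, a lower number a stronger inhibitor of growth), compound 1 gives 5300 nM. Of the two numbers shown, compound 1 has the lower one, but compound 2, with 5700 nM in this assay, sits within the scatter of it, so the two compounds cannot be told apart on this read-out. Compound 3 `C=CCOC(=O)Nc1ccc([Se]C#N)cc1` has not yet been measured. It differs from compound 1 in one place: vinyl in place of propyl on a saturated chain carbon bound to an oxygen next to a carbonyl group. Among the compounds with values here, no step between two measured compounds involves this kind of change, so the expectation rests on the small size of the change itself, with the carbamate and the selenocyanate of compound 1 left untouched. A step of no size beyond the scatter is expected, and the step from compound 1 to compound 3 in this assay is estimated as a 1.1-fold lower number from compound 1 to compound 3 (0.03 log units; within the scatter). Compound 3 is therefore expected to give about 5000 nM in this assay, within a range from 2500 nM to 10000 nM.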

Compound 3, concentration for 50% growth inhibition: 5000 nM
Compound 3: middle estimate and measured number agree at the digits printed; low and high end bracket the measured number.
By their numbers in this assay, from the lowest: compounds 3, 1 and 2 (each within the scatter of the next).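

In this assay, within the data shown here, vinyl in place of propyl on a saturated chain carbon bound to an oxygen next to a carbonyl group, the change from butoxy to allyloxy, gives a 1.1-fold lower number from compound 1 to compound 3 (0.03 log units; within the scatter) and so provides the first reading at this place. The two compounds cannot be told apart on this read-out, which shows that a double bond outside aromatic rings and a shorter saturated stretch can enter here with the carbamate and selenocyanate unchanged and no step beyond the scatter. No measured evidence bears on why this step is so small.

The compounds shown leave open whether a longer chain, a benzyl group or an amine at this place would give a step beyond the scatter. They also leave open how a thiocyanate in place of the selenocyanate would read.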